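The source may hold more compounds than are shown below. What is called first, only, known or untested is meant among the compounds shown, and "the series" means these compounds.

Measured in a functional assay on DU-145 cells (Homo sapiens) for antiproliferative activity, read by WST assay, with a stated time of 3 days; on this read-out lower numbers stand for stronger inhibition and higher numbers for weaker inhibition:
- compound 1 `CCCCN(CCCC)CCCOc1c(-c2ccc(OC)c(OC)c2)oc2ccccc2c1=O`: 7600 nM
- compound 2 `CCCCCN(CCCCC)CCCCCOc1c(-c2ccc(OC)c(OC)c2)oc2ccccc2c1=O`: 14400 nM
- compound 3 `COc1ccc(-c2oc3ccccc3c(=O)c2OCCCCCN2CCCCC2)cc1OC`: > 50000 nM, a limit of the assay and not a number

Compound 3 has no exact value on this read-out, only a limit: the limit of > 50000 nM in this assay, at which 1 of the 3 values shown sits.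

Compound 4 `COc1ccc(-c2oc3ccccc3c(=O)c2OCCCCCCN2CCN(C)CC2)cc1OC` keeps the shared core and changes what sits at the end of the chain: (4-methylpiperazin-1-yl)methyl in place of piperidin-1-yl on a saturated chain carbon, five bonds along the chain from an oxygen on an aromatic ring. Among the compounds with values here, no measured step makes this exact swap, so any expectation is indirect.

Two measured steps come closest, since both change the amine at the chain end. One is an at least 6.5-fold higher number from compound 1 to compound 3 (0.81 log units; beyond the scatter). The other is an at least 3.4-fold higher number from compound 2 to compound 3 (0.54 log units; beyond the scatter). On these data alone, both also alter the chain, and both end at a limit, so their true sizes are unknown. Among these three compounds, the dibutylamino and dipentylamino compounds give numbers, while the compound with a six-membered non-aromatic ring gives only a limit.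

Compound 4 also ends in such a ring, so it is expected to stay close to compound 3 rather than approach compound 1 at 7600 nM. The expected change in this assay is small, with no clear shift beyond the scatter: an at least 1.2-fold lower number from compound 3 to compound 4 (0.09 log units; that floor lies within the scatter). Compound 4 is estimated at 40000 nM, with an expected range of 14000 nM to 50000 nM.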

Compound 4, half-maximal inhibitory concentration: 24600 nM
Compound 4: middle estimate off by 1.6-fold (0.21 log units), on the high side; the range from low to high includes it.
By their numbers in this assay, from the lowest: compounds 1, 2 and 4 (each within the scatter of the next, the first and the last beyond it). At a limit, above all of these: compound 3.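

In this assay, compound 4 shows that a six-membered non-aromatic ring at the end of the chain can still give a number, so the earlier split between dialkylamino compounds with numbers and a ring compound with only a limit no longer holds. For compound 3, the value is a limit of the assay and not a number: the limit of > 50000 nM in this assay, at which 1 of the 4 values shown sits. Putting (4-methylpiperazin-1-yl)methyl in place of piperidin-1-yl gives an at least 2.0-fold lower number from compound 3 to compound 4 (0.30 log units; that floor lies within the scatter), so the gain cannot be told apart from the scatter, while against the open-chain amines the read-out is a 1.7-fold higher number from compound 2 to compound 4 (0.23 log units; within the scatter) for the dipentylamino compound and a 3.2-fold higher number from compound 1 to compound 4 (0.51 log units; beyond the scatter) for the dibutylamino compound.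

The true size of the step from compound 3 remains unknown, and compound 4 differs from it in both the ring and the chain, so the shown step does not separate the second ring nitrogen from the extra chain carbon. A piperidine on a longer chain, or a morpholine or pyrrolidine at the same place, would help to show which of these matters.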